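The source may report more compounds than this note shows. Statements on the series, on what has been measured and on what is new or still open speak of the compounds shown alone.

Measured so far in an assay on U2OS cells for inhibition of secreted frizzled-related protein 1 (Homo sapiens), read by a luciferase reporter, with a stated time of 18 h; a higher number here means that more compound is needed for the effect, a lower number that less compound is needed:
compound 1, `O=C(c1cccc(Cl)c1)N1CCC(NS(=O)(=O)c2cc(S(=O)(=O)c3ccccc3)ccc2C(F)(F)F)CC1`, 870 nM
compound 2, `O=C(c1ccc(C(F)(F)F)cc1)N1CCC(NS(=O)(=O)c2cc(S(=O)(=O)c3ccccc3)ccc2C(F)(F)F)CC1`, 970 nM
compound 3, `O=C(c1ccc(Cl)nc1)N1CCC(NS(=O)(=O)c2cc(S(=O)(=O)c3ccccc3)ccc2C(F)(F)F)CC1`, 140 nM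

Compound 3 holds the lowest number of the three. Its nearest neighbour is compound 1, and the step of a 6.2-fold lower number from compound 1 to compound 3 (0.79 log units; beyond the scatter) lies beyond the scatter; the step of a 6.9-fold lower number from compound 2 to compound 3 (0.84 log units; beyond the scatter) is a little larger. Compound 1 and compound 2 sit within the scatter of each other, as the step of a 1.1-fold higher number from compound 1 to compound 2 (0.05 log units; within the scatter) shows.

Compound 4, `CC(C)(C)OC(=O)N1CCC[C@@H]1C(=O)N1CCC(NS(=O)(=O)c2cc(S(=O)(=O)c3ccccc3)ccc2C(F)(F)F)CC1`, has not yet been measured. It differs from compound 3 in one place: 1-(tert-butoxycarbonyl)pyrrolidin-2-yl in place of 6-chloropyridin-3-yl on a carbonyl carbon. Within the data shown here, none of the measured steps matches this change closely. The two steps that touch the same carbonyl carbon, a 6.2-fold lower number from compound 1 to compound 3 (0.79 log units; beyond the scatter) and a 6.9-fold lower number from compound 2 to compound 3 (0.84 log units; beyond the scatter), both replace one six-membered aromatic ring with another; here the aromatic ring leaves altogether and a five-membered non-aromatic ring with a tert-butoxycarbonyl group enters. Among the measured compounds shown here, the only guidance is that the pyridinyl of compound 3 gave a modest gain over the two phenyl rings, so removing it is expected to surrender that gain.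

Compound 4 is therefore expected to give about 1500 nM in this assay, in a range of 300 nM to 8000 nM. That estimate means a step of an 11-fold higher number from compound 3 to compound 4 (1.03 log units; beyond the scatter), expected to lie beyond the scatter and toward a higher number.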

Compound 4, half-maximal effective concentration: 210 nM
Estimate against measurement, compound 4: 7.1-fold (0.85 log units) above; measured number outside the range, below it.
By their numbers in this assay, from the lowest: compounds 3 and 4 (each within the scatter of the next); then compounds 1 and 2 (each within the scatter of the next).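

The 3>4 comparison shows that the position on the carbonyl carbon, whose other neighbour is an amide-type nitrogen in a ring, does not require an aromatic ring in this assay: with a 1.5-fold higher number from compound 3 to compound 4 (0.18 log units; within the scatter), 1-(tert-butoxycarbonyl)pyrrolidin-2-yl and 6-chloropyridin-3-yl cannot be told apart, even though the former is larger and non-aromatic. The new group also stands clear of both phenyl groups, with a 4.6-fold lower number from compound 2 to compound 4 (0.66 log units; beyond the scatter) and a 4.1-fold lower number from compound 1 to compound 4 (0.62 log units; beyond the scatter), so among these four compounds the lower numbers are not confined to the pyridine ring. Nothing given here accounts for two such different groups giving values within the scatter of each other.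

The compounds shown leave open whether the result rests on the tert-butoxycarbonyl group or on the pyrrolidine ring, a question that a free ring amine or an acetyl group on the ring nitrogen would address. Also open, on these data alone, is what the defined stereocentre contributes, which the opposite enantiomer would test, and whether a plain cyclohexyl ring on the carbonyl carbon would fall with compound 3 and compound 4 or with the two phenyl compounds.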